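Inverting one stereocentre of compound 3

The source may hold more compounds than are shown below. What is called first, only, known or untested is meant among the compounds shown, and "the series" means these compounds.

Measured in an ADME assay on Vero cells (Chlorocebus sabaeus) for cytotoxicity, read by MTT assay, with a stated time of 72 h; on this read-out higher numbers stand for lower toxicity in this test and lower numbers for higher toxicity in this test:
- Compound 1 `COc1ccc([C@@H](O)COC(=O)/C=C/c2ccccc2)cc1`: 23300 nM
- Compound 2 `O=C(/C=C/c1ccccc1)OC[C@H](O)c1ccccc1`: 30300 nM
- Compound 3 `Cc1ccc([C@H](O)COC(=O)/C=C/c2ccccc2)cc1`: > 200000 nM

Compound 3 stands at the limit of > 200000 nM in this assay, at which 1 of the 3 values shown sits, a limit and not a number. Compound 4 `Cc1ccc([C@@H](O)COC(=O)/C=C/c2ccccc2)cc1` departs from it in one respect: the two compounds have the same atoms and bonds and differ only in configuration as drawn: 1 of 2 stereo elements differ; a stereocentre at a saturated chain carbon is drawn S in compound 3 and R in compound 4. Among the measured compounds shown here, no measured step shows the effect of such an inversion. For the measured compounds named here, the only measured step, a 1.3-fold higher number from compound 1 to compound 2 (0.11 log units; within the scatter), concerns hydrogen in place of methoxy. However, that stereocentre is drawn R in compound 1 and in compound 2, as in compound 4, and a 1.3-fold higher number from compound 1 to compound 2 (0.11 log units; within the scatter) puts those two within the scatter of each other. A move to a lower number, meaning higher toxicity, is therefore expected, although compound 4 may also reach the limit. The expected step is an at least 5.0-fold lower number from compound 3 to compound 4 (0.69 log units; beyond the scatter). Compound 4 is estimated at 40000 nM, with an expected range from 15000 nM to 200000 nM.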

Compound 4, half-maximal cytotoxic concentration: > 200000 nM
Compound 4: only a limit was reported (the forecaster's own chance of this, stated with the estimate: 25%); at least 5.0-fold (0.69 log units) between middle value and limit.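

In this assay compound 4 gives > 200000 nM, a limit and not a number, and the step to it from compound 3 cannot be read: the limit of > 200000 nM in this assay, at which 2 of the 4 values shown sit. With the stereocentre drawn R throughout, methyl on the aromatic carbon still gives an at least 6.6-fold higher number from compound 2 to compound 4 (0.81 log units; beyond the scatter) and an at least 8.5-fold higher number from compound 1 to compound 4 (0.93 log units; beyond the scatter). The high number of compound 3 therefore does not depend on the S configuration alone, and among these compounds it follows the methyl group in either configuration.

From the compounds shown here alone, what the inversion does at this position remains open, since both methyl compounds sit at the limit. Also open, going by these compounds, is whether an ethyl group or a chlorine atom on that aromatic carbon would behave as methyl does.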